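The source may report more compounds than this note shows. Statements on the series, on what has been measured and on what is new or still open speak of the compounds shown alone.

Compound 2 `Nc1nc2c(nc(I)n2COCCO)c(=O)[nH]1` carries iodo where compound 1 `Nc1nc2c(nc(Cl)n2COCCO)c(=O)[nH]1` carries chloro. In a functional assay (Oryctolagus cuniculus) for inhibition (on this read-out lower numbers stand for stronger inhibition and higher numbers for weaker inhibition), compound 1 gives only a limit, > 400 ug/mL. Compound 2 in this assay likewise reaches only a limit, >= 350 ug/mL. For the measured compounds named here, the one measured step, a step that the two limits leave unreadable from compound 1 to compound 2, cannot be sized; compound 2 stands at a limit, and so does the other value shown, as the lines the limit of > 400 ug/mL in this assay, at which 1 of the 2 values shown sits, and the limit of >= 350 ug/mL in this assay, at which 1 of the 2 values shown sits, record.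

Compound 3 `Nc1nc2c(nc(O)n2COCCO)c(=O)[nH]1` differs from compound 2 by hydroxy in place of iodo on an aromatic carbon. Going by the values given here, no measured step bears directly on this change: the only step recorded, iodo in place of chloro, has both its ends at limits and says nothing about the size or direction of swapping a halogen for hydroxy at this carbon. With both measured compounds sitting at a limit in this assay, compound 3 is expected to sit near the same limit, the expected step that the limit leaves unreadable from compound 2 to compound 3 being none beyond the scatter. Compound 3 is therefore estimated at 400 ug/mL, within 150 ug/mL to 1000 ug/mL, and most likely returned once more as a limit rather than a number.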

Compound 3, concentration for 50% inhibition: 48 ug/mL
Compound 3: middle estimate off by 8.3-fold (0.92 log units), on the high side; measured number below the stated range.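

In this assay, the carbon between two ring nitrogen atoms now proves responsive to its substituent: hydroxy in place of iodo gives an at least 7.2-fold lower number from compound 2 to compound 3 (0.86 log units; beyond the scatter), and hydroxy in place of chloro gives an at least 8.3-fold lower number from compound 1 to compound 3 (0.92 log units; beyond the scatter). Of the groups shown at this carbon, hydroxy alone gives a number rather than a limit, which the pair of halogen compounds could not reveal. Each step is only a lower bound on the real difference because its halogen end is a limit, as for compound 1 and likewise for compound 2: the limit of > 400 ug/mL in this assay, at which 1 of the 3 values shown sits.

The steps between the two halogen compounds cannot be read, so chloro and iodo remain unordered, and the compounds shown do not separate a gain from hydroxy itself from a loss on removing the halogen. Also open, on these data alone, is whether an amine, a methoxy group or plain hydrogen at this carbon would give a number in this assay, and whether the result holds when the (2-hydroxyethoxy)methyl group is replaced by a shorter or longer chain.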